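Permeability after capping an amine as a urea

The source may report more compounds than this note shows. Statements on the series, on what has been measured and on what is new or still open speak of the compounds shown alone.

Compound 1 `CC(C)S(=O)(=O)NC(=O)c1ccc(Nc2nc(NC3(c4ccc(Cl)cc4)CC3)nc(OCC(F)(F)F)n2)cc1`: 31 nm/s
Compound 2 `NCCS(=O)(=O)NC(=O)c1ccc(Nc2nc(NC3(c4ccc(Cl)cc4)CC3)nc(OCC(F)(F)F)n2)cc1`: 153 nm/s

Among the measured compounds shown here, in a physicochemical assay for permeability, using PAMPA, at pH 7.4 (on this read-out higher numbers stand for higher permeability and lower numbers for lower permeability), compound 2 gives 153 nm/s, the higher of the two numbers, the only step to it being a 4.9-fold higher number from compound 1 to compound 2 (0.69 log units; beyond the scatter). Compound 3 `CC(C)NC(=O)NCCS(=O)(=O)NC(=O)c1ccc(Nc2nc(NC3(c4ccc(Cl)cc4)CC3)nc(OCC(F)(F)F)n2)cc1` differs from compound 2 by isopropylcarbamoyl in place of hydrogen on an amine nitrogen. That single measured step changed what sits on the sulfonyl sulfur, not on the amine nitrogen, so it gives no close guide here. Compound 3 is therefore expected to show only a modest step, probably downward, a 2.2-fold lower number from compound 2 to compound 3 (0.34 log units; beyond the scatter), and its number in this assay is estimated at 70 nm/s, in the range 20 nm/s to 250 nm/s.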

Compound 3, apparent permeability: 45 nm/s
For compound 3 the middle estimate is 1.6-fold (0.19 log units) above the measured one; the range from low to high includes it.
By their numbers in this assay, from the lowest: compounds 1 and 3 (each within the scatter of the next); then compound 2.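

In this assay isopropylcarbamoyl on the amine nitrogen gives a 3.4-fold lower number from compound 2 to compound 3 (0.53 log units; beyond the scatter) and so shows that this nitrogen, untouched by the earlier step, is also a place where a change registers. Set against isopropyl on the sulfonyl sulfur, 2-((isopropylcarbamoyl)amino)ethyl gives a 1.5-fold higher number from compound 1 to compound 3 (0.16 log units; within the scatter) and so cannot be told apart from it. Nothing at hand accounts for these steps.

The compounds shown leave open what a carboxylic acid or a longer chain would give on the sulfonyl sulfur. They also leave open whether an acetyl group on the amine nitrogen would match isopropylcarbamoyl.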